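The source may hold more compounds than are shown below. What is called first, only, known or untested is meant among the compounds shown, and "the series" means these compounds.

Compound 1, `CCCn1c(=O)[nH]c2nc(-c3ccc(S(=O)(=O)N4CCN(C)CC4)cc3)[nH]c2c1=O`, gives > 1000 nM in an assay on CHO cells for displacement of a labelled ligand from adenosine receptor A3 (Homo sapiens), read by scintillation counting, with a stated time of 45 min, in the presence of a further agent that is not named here (on this read-out higher numbers stand for weaker inhibition and lower numbers for stronger inhibition), which is a limit of the assay.
Compound 2, `CCCn1c(=O)[nH]c2nc(-c3ccc(S(=O)(=O)N4CCN(Cc5cccc(Br)c5)CC4)cc3)[nH]c2c1=O`, gives > 1000 nM in this assay, again only a limit.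
Compound 3, `CCCn1c(=O)[nH]c2nc(-c3ccc(S(=O)(=O)N4CCN(c5ccc(C)cc5)CC4)cc3)[nH]c2c1=O`, gives > 1000 nM in this assay, also a limit and not a number.

Compound 3 therefore stands at the limit, and so do the two other measured compounds, as the limit of > 1000 nM in this assay, at which 3 of the 3 values shown sit, shows. The steps among the three, a step that the two limits leave unreadable from compound 1 to compound 2, a step that the two limits leave unreadable from compound 1 to compound 3 and a step that the two limits leave unreadable from compound 2 to compound 3, cannot be sized, since both ends of each sit at the limit. Compound 4, `CCCn1c(=O)[nH]c2nc(-c3ccc(S(=O)(=O)N4CCN(c5cccc(F)c5)CC4)cc3)[nH]c2c1=O`, differs from compound 3 by 3-fluorophenyl in place of 4-methylphenyl on an amine nitrogen in a ring. The measured steps bear on this change only in showing that neither methyl, nor 3-bromobenzyl, nor 4-methylphenyl on the amine nitrogen in the ring brought the value inside the measurable range. The expected step is a step that the limit leaves unreadable from compound 3 to compound 4, that is, no change beyond the scatter, with compound 4 most likely also reported as a limit. Compound 4 is estimated at 3000 nM, with a range from 800 nM to 20000 nM.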

Compound 4, inhibition constant: > 1000 nM
Compound 4 was reported as a limit; the forecaster's own chance of this, stated with the estimate: 80%; the middle value does not contradict the limit.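

In this assay compound 4 gives > 1000 nM, again only a limit. No step among compound 1, compound 2, compound 3 and compound 4 can be read, because all four sit at one limit: the limit of > 1000 nM in this assay, at which 4 of the 4 values shown sit.

The compounds shown leave open whether any group on the amine nitrogen in the ring brings the value inside the measurable range.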